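Naphthyl for trifluoromethylphenyl on the piperazine nitrogen

This account rests on a few compounds, and the source may have more. Where it says the series, first, only, none or still open, it means among the compounds named here.

Compound 1 `Nc1scc(CN2CCN(c3cccc(C(F)(F)F)c3)CC2)c1C(=O)c1ccc(Cl)cc1` is examined in an assay on CHO cells for displacement of a labelled ligand from adenosine receptor A3 (Homo sapiens), read by scintillation counting, with a stated time of 120 min, tested at 10 uM (on this read-out lower numbers stand for less inhibition and higher numbers for more inhibition at the one concentration tested (going by the name of the read-out)), where compound 1 gives 0%. Compound 3 `Nc1scc(CN2CCN(c3cccc(F)c3)CC2)c1C(=O)c1cccc(C(F)(F)F)c1` gives 0% in this assay, no change from compound 1 at the digits reported. Compound 2 `Nc1scc(CN2CCC(c3ccc(Cl)cc3)CC2)c1C(=O)c1ccc(Cl)cc1` gives 6% in this assay, a number that stays within the scatter of compound 1. No pair among these three differs in one place only, so no single step has been measured.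

Compound 4 `Nc1scc(CN2CCN(c3cccc4ccccc34)CC2)c1C(=O)c1ccc(Cl)cc1` differs from compound 1 by naphthalen-1-yl in place of 3-(trifluoromethyl)phenyl on an amine nitrogen in a ring. With the three numbers so close, no step beyond the scatter is expected in either direction for this assay. Compound 4 is estimated at 5%, in the range -8% to 25%, which means an expected step of a number 5 percentage points higher from compound 1 to compound 4 (within the scatter).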

Compound 4, a percentage reported as inhibition, at one concentration (the size of the read-out at that concentration, not a potency): 0%
For compound 4 the middle estimate is 5 percentage points above the measured one; low and high end bracket the measured number.
By their numbers in this assay, from the lowest: compounds 1, 3, 4 and 2 (each within the scatter of the next).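

In this assay, among the compounds shown here, naphthalen-1-yl in place of 3-(trifluoromethyl)phenyl on an amine nitrogen in a ring gives no change at the digits printed from compound 1 to compound 4 (within the scatter) and is the first single step read. At this position, a second six-membered aromatic ring of carbon only, at an equal heavy-atom count, thus leaves the read-out unmoved. No measured property bears on this result.

From the compounds shown here alone, what a benzyl group or a pyridine ring on this nitrogen would give remains open. So does whether the same exchange would register on a compound with a higher reading.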